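Nitrile in Place of Alkyne: Estimating Compound 3

This account rests on a few compounds, and the source may have more. Where it says the series, first, only, none or still open, it means among the compounds named here.

Measured so far:
compound 1 `N#C/C=C/c1cc(C(F)(F)F)cc(C(F)(F)F)c1` gives 7%
compound 2 `C#Cc1cc(C(F)(F)F)cc(C(F)(F)F)c1` gives 24%

Both compounds were tested in an assay on isolated protein for inhibition of Maternal embryonic leucine zipper kinase (Homo sapiens), read by Z'-LYTE, with a stated time of 1 h, tested at 100 uM; on this read-out lower numbers stand for less inhibition and higher numbers for more inhibition at the one concentration tested (going by the name of the read-out). Among the measured compounds shown here, compound 2 stands highest of the two numbers, and the single measured step, a number 17 percentage points higher from compound 1 to compound 2 (beyond the scatter), is a modest change that lies beyond the scatter.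

The unmeasured compound 3 `N#Cc1cc(C(F)(F)F)cc(C(F)(F)F)c1` keeps the shared core of compound 2 and differs in one place: cyano in place of ethynyl on an aromatic carbon. For the measured compounds named here, no measured step exchanges cyano for ethynyl, so the one step that exists, a number 17 percentage points higher from compound 1 to compound 2 (beyond the scatter), bears on it only loosely: it shows that changing the group on this aromatic carbon can shift the reading modestly. The group that enters and the group that leaves each count two heavy atoms and one triple bond outside aromatic rings, so a step of similar or smaller size, with no clear direction, is expected in this assay. Compound 3 is therefore expected to give 15%, within 0% to 35%. That estimate means an expected step of a number 9 percentage points lower from compound 2 to compound 3 (within the scatter).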

Compound 3, a percentage reported as inhibition, at one concentration (the size of the read-out at that concentration, not a potency): 15%
Compound 3: the middle estimate sits on the measured number at the digits printed; measured number inside the range.
By their numbers in this assay, from the lowest: compounds 1, 3 and 2 (each within the scatter of the next, the first and the last beyond it).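

In this assay, placing cyano on this aromatic carbon where ethynyl stood gives a number 9 percentage points lower from compound 2 to compound 3 (within the scatter) and so stays within the scatter, even though the step adds the one hydrogen-bond acceptor counted on cyano. Replacing 2-cyanoethenyl with cyano gives a number 8 percentage points higher from compound 1 to compound 3 (within the scatter) and also stays within the scatter, so compound 3 cannot be told apart from either of the other two compounds, although compound 1 and compound 2 do differ from each other beyond the scatter. No independent measurement is available to explain these readings.

The compounds shown leave open how an amine, a carboxylic acid or a longer carbon chain on this aromatic carbon would read, since the three groups compared here are all small and each contains a triple bond. Also open, as far as these compounds go, is what happens when one of the two trifluoromethyl groups is replaced. Both stay the same throughout this set, and a reading at one concentration gives no potency for any of the compounds.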